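The source may report more compounds than this note shows. Statements on the series, on what has been measured and on what is new or still open speak of the compounds shown alone.

Measured so far in a functional assay on UACC-62 cells (Homo sapiens) for inhibition, read by sulforhodamine B assay, with a stated time of 48 h; a higher number here means that more compound is tolerated, a lower number that less compound is tolerated:
compound 1 `O=C(Nc1cccc(-n2cc(-c3ccncc3)c(-c3ccc(Cl)c(O)c3)n2)c1)Nc1ccc(Cl)c(Cl)c1` gives 29200 nM.
Compound 2 `COc1cc(-c2nn(-c3cccc(NC(=O)c4ccc(Cl)c(C(F)(F)F)c4)c3)cc2-c2ccncc2)ccc1Cl` gives a limit, > 32500 nM.
Compound 3 `COc1cc(-c2nn(-c3cccc(NC(=O)c4cccc(C(F)(F)F)c4)c3)cc2-c2ccncc2)ccc1Cl` gives a limit, > 50000 nM.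

Compound 3 therefore stands only at a limit, with one further value among the three also a limit. The step that the two limits leave unreadable from compound 2 to compound 3 cannot be read, because the limit of > 32500 nM in this assay, at which 1 of the 3 values shown sits, and the limit of > 50000 nM in this assay, at which 1 of the 3 values shown sits, cap both readings.

Compound 4 `COc1cc(-c2nn(-c3cccc(NC(=O)Nc4cccc(C(F)(F)F)c4)c3)cc2-c2ccncc2)ccc1Cl` differs from compound 3 by (3-(trifluoromethyl)phenyl)amino in place of 3-(trifluoromethyl)phenyl on a carbonyl carbon. Going by the values given here, no measured step covers this change; compound 1, on a differently substituted core, gives 29200 nM but offers no direct step. With compound 3 already at a limit, no step beyond the scatter is expected, and a further limit is likely. Compound 4 is estimated at 45000 nM (15000 nM to 100000 nM), an expected step of an at least 1.1-fold lower number from compound 3 to compound 4 (0.04 log units; that floor lies within the scatter).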

Compound 4, concentration lethal to 50% of the cells: 3480 nM
Estimate against measurement, compound 4: 13-fold (1.11 log units) above; measured number below the stated range.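

Going by these compounds alone, on a carbonyl carbon, (3-(trifluoromethyl)phenyl)amino in place of 3-(trifluoromethyl)phenyl gives the first readable change at this position in this assay: an at least 14-fold lower number from compound 3 to compound 4 (1.15 log units; beyond the scatter). With 4-chloro-3-(trifluoromethyl)phenyl as the group replaced, the result is an at least 9.3-fold lower number from compound 2 to compound 4 (0.97 log units; beyond the scatter). The size of the first step remains a floor, because compound 3 stands at a limit: the limit of > 50000 nM in this assay, at which 1 of the 4 values shown sits.

Left open is whether the hydrogen on the entering nitrogen accounts for the step. A methyl group on that nitrogen would separate the hydrogen from the nitrogen itself.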